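The compounds below may be only part of what the source reports. "The series", "measured", "known", "first", "only" and "open" are said of these compounds alone.

In a functional assay for inhibition, with Homo sapiens as the target (on this read-out lower numbers stand for stronger inhibition and higher numbers for weaker inhibition), compound 1 `O=C(O)CCCCCCn1nc(-c2ccccc2)c(-c2ccccc2)c1-c1ccccc1` gives 22400 nM, the higher of the two numbers in the series. Compound 3 `O=C(O)CCCCCCCCn1cc(-c2ccccc2)c(-c2ccccc2)n1` gives 4500 nM. Compound 2 `O=C(O)CCCCCCn1cc(-c2ccccc2)c(-c2ccccc2)n1` reads > 92000 nM, which is a limit of the assay. Compound 4 `CC(C)(C)OC(=O)COCCCCCCn1nc(-c2ccccc2)c(-c2ccccc2)c1-c1ccccc1` departs from compound 1 on the chain: (tert-butoxycarbonyl)methoxy in place of carboxy on a saturated chain carbon, six bonds along the chain from an aromatic nitrogen. The closest measured change at that place is an at least 20-fold lower number from compound 2 to compound 3 (1.31 log units; beyond the scatter), with 2-carboxyethyl in place of carboxy. The change on the core, an at least 4.1-fold higher number from compound 1 to compound 2 (0.61 log units; beyond the scatter), bears only indirectly. Both steps retain carboxy, whereas compound 4 loses it, so neither carries over directly. The expected step is a 1.3-fold higher number from compound 1 to compound 4 (0.13 log units; within the scatter), none beyond the scatter, with wide uncertainty. For compound 4 the estimated value is 30000 nM, within 6000 nM to 150000 nM.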

Compound 4, half-maximal inhibitory concentration: > 62000 nM
Compound 4: only a limit was reported (the forecaster's own chance of this, stated with the estimate: 30%); middle value at least 2.0-fold (0.31 log units) away from the limit.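

At this place, on a saturated chain carbon, six bonds along the chain from an aromatic nitrogen, (tert-butoxycarbonyl)methoxy in place of carboxy gives an at least 2.7-fold higher number from compound 1 to compound 4 (0.44 log units; beyond the scatter). Compound 4 is the only compound shown without carboxy, and inhibition in this assay weakens with this change on the core of compound 1. The reading for compound 4 is only a limit: the limit of > 62000 nM in this assay, at which 1 of the 4 values shown sits.

Open, from the compounds shown here alone, is whether the weakening follows the loss of the free acid or the larger chain end. A carboxylic acid in place of the tert-butyl ester, giving a carboxymethoxy end on the same chain, would separate the two.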